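Trifluoromethoxy for chloro on an alkyne-linked thiazole series

The compounds below may be only part of what the source reports. "The series", "measured", "known", "first", "only" and "open" are said of these compounds alone.

Measured compounds in a functional assay on CHO cells for agonist activity at metabotropic glutamate receptor 5 (Homo sapiens), read by inositol phosphate accumulation; a lower number here means a stronger inhibitor, a higher number a weaker inhibitor:
compound 1, `Cc1nc(C#Cc2ccc(F)cc2)cs1`, gives 2970 nM
compound 2, `COc1cccc(C#Cc2csc(C)n2)c1`, gives 49 nM
compound 3, `Cc1nc(C#Cc2cccc(Cl)c2)cs1`, gives 129 nM

Among these three, compound 3 stands second highest. Among the measured compounds shown here, its nearest neighbour is compound 2, whose value sits lower, and the step of a 2.6-fold higher number from compound 2 to compound 3 (0.42 log units; beyond the scatter) is the one measured change within this set; compound 1, with a different substitution pattern on the same ring, lies far above both. For the measured compounds named here, no step is recorded between compound 1 and compound 3, so their two values are simply what they show.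

Compound 4, `Cc1nc(C#Cc2cccc(OC(F)(F)F)c2)cs1`, is not yet measured. It differs from compound 3 in one place: trifluoromethoxy in place of chloro on an aromatic carbon. Going by the values given here, the only measured step that bears on this change is the swap on the same aromatic carbon from compound 2 to compound 3, which was of modest size. Among the compounds with values here, with only that single comparison available, and no measured example of a trifluoromethoxy group anywhere in this set, the direction of the change cannot be taken from the data with confidence. The expectation is therefore a small step, a 1.2-fold higher number from compound 3 to compound 4 (0.07 log units; within the scatter), within or only slightly beyond the scatter. Compound 4 is expected to give about 150 nM in this assay, in a range from 50 nM to 500 nM.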

Compound 4, half-maximal inhibitory concentration: 266 nM
Compound 4: the middle estimate sits 1.8-fold (0.25 log units) below what was measured; low and high end bracket the measured number.
By their numbers in this assay, from the lowest: compound 2; then compound 3; then compound 4; then compound 1.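

In this assay, the same aromatic carbon has now carried three groups, and each of the three steps between them lies beyond the scatter, so the position distinguishes methoxy, chloro and trifluoromethoxy, with compound 2 lowest and compound 4 highest of the three. Trifluoromethoxy in place of chloro gives a 2.1-fold higher number from compound 3 to compound 4 (0.31 log units; beyond the scatter) and trifluoromethyl in place of methyl on the oxygen gives a 5.4-fold higher number from compound 2 to compound 4 (0.73 log units; beyond the scatter), which shows that an oxygen on this carbon does not by itself keep the number as low as in compound 2. No measurement is available that would explain this order.

The compounds shown leave open how other groups would rank on this carbon, such as a trifluoromethyl group bonded directly to the ring without the oxygen, an amine, a nitrile or a longer alkoxy chain. They also leave open whether the order of methoxy, chloro and trifluoromethoxy would hold on another carbon of the ring or with a different group in place of the methyl on the shared core.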